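Sulfonamide nitrogen substituent in meta-benzohydroxamic acid inhibitors

The compounds below may be only part of what the source reports. "The series", "measured", "known", "first", "only" and "open" are said of these compounds alone.

Measured compounds:
compound 1 `C[C@H](NS(=O)(=O)c1cccc(C(=O)NO)c1)C(=O)Nc1ccccc1` 24200 nM
compound 2 `O=C(NO)c1cccc(S(=O)(=O)Nc2ccccc2)c1` 50 nM

In an assay on isolated protein for inhibition of histone deacetylase 8 (Homo sapiens), read by fluorescence, with stated times of 5 min and 30 min (on this read-out lower numbers stand for stronger inhibition and higher numbers for weaker inhibition), compound 2 gives the lower of the two numbers; compound 1 gives 24200 nM, a gap well beyond the scatter. Compound 3 `O=C(NO)c1cccc(S(=O)(=O)NCc2ccccc2)c1` is not yet measured. It differs from compound 2 in one place: benzyl in place of phenyl on a sulfonamide nitrogen.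

Among the measured compounds shown here, no step between two measured compounds is available to gauge this change. Compound 3 is expected to fall somewhat weaker than compound 2, by a step of a 4.0-fold higher number from compound 2 to compound 3 (0.60 log units; beyond the scatter) in this assay, beyond the scatter. The estimate for compound 3 is 200 nM, with a range from 60 nM to 900 nM.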

Compound 3, half-maximal inhibitory concentration: 80 nM
Estimate against measurement, compound 3: 2.5-fold (0.40 log units) above, within the range that was stated.
By their numbers in this assay, from the lowest: compounds 2 and 3 (each within the scatter of the next); then compound 1.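

In this assay, among the compounds shown here, benzyl in place of phenyl on the sulfonamide nitrogen gives a 1.6-fold higher number from compound 2 to compound 3 (0.20 log units; within the scatter), the first one-place step at this position. Compound 2 and compound 3 therefore cannot be told apart, and this nitrogen accepts either group in this assay. No independent measurement bears on why the two groups read alike.

The compounds shown leave open whether an aromatic ring on this nitrogen is needed, which a simple methyl group would address. From the compounds shown here alone, how a longer phenethyl chain, or an amine or carboxylic acid on the benzyl ring, would read also remains open.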